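Dropping one phenyl from compound 2

The source may report more compounds than this note shows. Statements on the series, on what has been measured and on what is new or still open speak of the compounds shown alone.

In a functional assay on MCF7 cells (Homo sapiens) for inhibition (a lower number here means a stronger inhibitor, a higher number a weaker inhibitor), compound 1 `CCC(C)C(NC(=O)NO)C(=O)NC(c1ccccc1)c1ccccc1` gives 17800 nM. Compound 2 `CCC(C)C(NC(=O)n1nnc2ccccc21)C(=O)NC(c1ccccc1)c1ccccc1` gives > 100000 nM, which is a limit and not a number. Compound 3 `CC(C)C(NC(=O)NO)C(=O)NC1CCCC1` gives > 100000 nM, also a limit. Compound 2 thus stands at the limit of > 100000 nM in this assay, at which 2 of the 3 values shown sit.

Compound 4 `CCC(C)C(NC(=O)n1nnc2ccccc21)C(=O)NCc1ccccc1` has hydrogen in place of phenyl on a saturated chain carbon bound to an amide-type nitrogen and an aromatic carbon. Within the data shown here, the only measured step, an at least 5.6-fold higher number from compound 1 to compound 2 (0.74 log units; beyond the scatter), concerns the group on a carbonyl carbon, not this place, so it sets no size for this change. No step beyond the scatter is expected, and another limit reading is likely. The expected step is a number no higher from compound 2 to compound 4 (the limit leaves the size open). For compound 4 the estimate is 100000 nM. The expected range for compound 4 is 40000 nM to 200000 nM.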

Compound 4, half-maximal inhibitory concentration: 69200 nM
The estimate for compound 4 lay 1.4-fold (0.16 log units) above the measured number; the measured number falls inside the stated range.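

In this assay, hydrogen in place of phenyl on the saturated chain carbon bound to an amide-type nitrogen and an aromatic carbon gives an at least 1.4-fold lower number from compound 2 to compound 4 (0.15 log units; that floor lies within the scatter). Removing this phenyl therefore brings no readable loss of inhibition, and compound 4 is the only compound shown with the nine-atom group on the carbonyl carbon that reads as a number rather than a limit. On these data alone, the step has only a floor, so its true size stays unknown.

As far as these compounds go, how a methyl group or an amine at this carbon would read remains open. So does the same phenyl-to-hydrogen change on compound 1.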